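The compounds below may be only part of what the source reports. "The series", "measured", "known", "first", "only" and "open" are said of these compounds alone.

Measured so far in an ADME assay on J774 cells (Mus musculus) for cytotoxicity, read by MTT assay, with a stated time of 48 h, tested at 50 ug/mL; a higher number here means a weaker effect of the compound at the concentration tested, a lower number a stronger effect:
compound 1 `O=C(N/N=C/c1ccccc1Cl)c1cnccn1`, 70%;
compound 2 `O=C(N/N=C/c1ccc(Cl)cc1)c1cnccn1`, 83%;
compound 3 `O=C(N/N=C/c1ccccc1O)c1cnccn1`, 1%.

Compound 2 gives the highest number of the three in this assay, beyond the scatter above compound 1 and far above compound 3. The change to compound 4 `O=C(N/N=C/c1ccc(O)cc1)c1cnccn1` is hydroxy in place of chloro on an aromatic carbon, sited para to a large group. For the measured compounds named here, one measured step bears on it directly, a number 69 percentage points lower from compound 1 to compound 3 (beyond the scatter), a large fall for the same kind of exchange. Going by the values given here, a fall of comparable size is therefore expected for compound 4 in this assay, with a wide range since the carbon carrying the change is not the one changed between compound 1 and compound 3. The expected step is a number 58 percentage points lower from compound 2 to compound 4 (beyond the scatter). Compound 4 is estimated at 25%, with a range from 3% to 60%.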

Compound 4, a percentage reported as activity, at one concentration (the size of the read-out at that concentration, not a potency): 100%
Beside the measured number, compound 4's estimate is 75 percentage points below it; the whole stated range lies below it.
By their numbers in this assay, from the lowest: compound 3; then compound 1; then compound 2; then compound 4.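

Hydroxy in place of chloro, para to a large group, gives a number 17 percentage points higher from compound 2 to compound 4 (beyond the scatter) in this assay. The direction of this exchange is therefore not fixed across the series, and the outcome depends on the carbon that carries it: the same change on two cores in this assay, a number 69 percentage points lower (beyond the scatter) from compound 1 to compound 3 and a number 17 percentage points higher (beyond the scatter) from compound 2 to compound 4, 86 percentage points apart, beyond the scatter of two such steps

From the compounds shown here alone, what stays open is whether the rise belongs to hydroxy itself or would also appear with other groups on that carbon. An amine or a methoxy group there would test this, and the same groups on the carbon changed in compound 3 would show whether its fall is specific to hydroxy.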